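Taking the tert-butyl off compound 1: expected permeability

The source may hold more compounds than are shown below. What is called first, only, known or untested is meant among the compounds shown, and "the series" means these compounds.

Going by the values given here, compound 1 `CC(C)(C)c1ccc(Oc2ccc3c(NCCCNCc4ccco4)ccnc3c2)cc1` is one of three compounds measured in an ADME assay for permeability, using PAMPA, with a stated time of 30 min, at pH 7.4 (on this read-out lower numbers stand for lower permeability and higher numbers for higher permeability), where compound 1 gives 317 10^-6 cm/s. Compound 2 `COc1ccc(Oc2ccc3c(NCCCNCc4cc(F)ccc4OC)ccnc3c2)cc1` gives 317 10^-6 cm/s in this assay, and compound 3 `COc1ccc(F)cc1CNCCCNc1ccnc2cc(Oc3ccc(F)cc3)ccc12` gives 317 10^-6 cm/s. The one measured step, no change at the digits printed from compound 2 to compound 3 (within the scatter), shows no movement within the scatter, and compound 1 stands level with both compound 2 and compound 3 at the digits shown.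

Compound 4 `c1ccc(Oc2ccc3c(NCCCNCc4ccco4)ccnc3c2)cc1` differs from compound 1 in a single place: hydrogen in place of tert-butyl on an aromatic carbon. Among the compounds with values here, no measured step removes a tert-butyl, so the step from compound 1 to compound 4 has no direct precedent; the measured step of no change at the digits printed from compound 2 to compound 3 (within the scatter) concerns a different exchange and moved nothing. With all three measured compounds at the same reading in this assay, the expected step for compound 4 is a 1.1-fold lower number from compound 1 to compound 4 (0.02 log units; within the scatter), none beyond the scatter. Compound 4 is therefore estimated at 300 10^-6 cm/s, with a range from 150 10^-6 cm/s to 320 10^-6 cm/s.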

Compound 4, apparent permeability: 317 10^-6 cm/s
Compound 4: middle estimate off by 1.1-fold (0.02 log units), on the low side; measured number inside the range.
By their numbers in this assay, from the lowest: compounds 1, 2, 3 and 4 (each within the scatter of the next).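

Going by these compounds alone, with the tert-butyl removed, this assay shows no change at the digits printed from compound 1 to compound 4 (within the scatter), so this is the first measured step in which a group on this carbon gives way to hydrogen alone. The reading does not separate 4-(tert-butyl)phenyl from phenyl in the setting of compound 1, which extends the flat picture left by no change at the digits printed from compound 2 to compound 3 (within the scatter) to a change that removes a whole group and puts no other in its place. Nothing available accounts for this reading.

As far as these compounds go, whether an amine or a carboxylic acid on this same aromatic carbon would leave the reading where it stands remains open. Also open, from the compounds shown here alone, is whether a longer chain in the side arm of compound 1 would move the number at all.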